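Diaryl-pyrimidine amides at the human adenosine A3 receptor

The source may hold more compounds than are shown below. What is called first, only, known or untested is meant among the compounds shown, and "the series" means these compounds.

Measured compounds:
- compound 1, `COc1ccc(-c2cc(NC(=O)COCC(=O)N(C)CC(=O)NC3CCCCC3)nc(-c3ccc(OC)cc3)n2)cc1`: 10100 nM
- compound 2, `COc1ccc(-c2cc(NC(=O)COCC(=O)N(C)CC(=O)NCc3ccccc3)nc(-c3ccc(OC)cc3)n2)cc1`: 19000 nM
- compound 3, `COc1ccc(-c2cc(NC(=O)COCC(=O)N3CCN(CC(=O)NC4CCCCC4)CC3)nc(-c3ccc(OC)cc3)n2)cc1`: 18300 nM

All three numbers come from an assay on HeLa cells for displacement of a labelled ligand from adenosine receptor A3 (Homo sapiens), read by fluorescence polarization, with a stated time of 30 min (on this read-out higher numbers stand for weaker inhibition and lower numbers for stronger inhibition), and lie within the usual scatter of one another, so no order among them is claimed. The change from compound 1 to compound 2 is benzyl in place of cyclohexyl on an amide-type nitrogen; it gave a 1.9-fold higher number from compound 1 to compound 2 (0.27 log units; within the scatter).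

Compound 4, `COc1ccc(-c2cc(NC(=O)COCC(=O)N3CCN(CC(=O)NCc4ccccc4)CC3)nc(-c3ccc(OC)cc3)n2)cc1`, carries the same change on the core of compound 3: benzyl in place of cyclohexyl on an amide-type nitrogen. The difference between the core of compound 1 and the core of compound 3 is not broken down here.

The step from compound 3 to compound 4 in this assay is expected to resemble the earlier one, a 1.6-fold higher number from compound 3 to compound 4 (0.21 log units; within the scatter), because compound 1 to compound 2 gave a 1.9-fold higher number from compound 1 to compound 2 (0.27 log units; within the scatter). Compound 4 is therefore estimated at 30000 nM, between 12000 nM and 75000 nM.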

Compound 4, inhibition constant: 9300 nM
Compound 4: middle estimate off by 3.2-fold (0.51 log units), on the high side, and the stated range ends above it.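

In this assay, benzyl in place of cyclohexyl on an amide-type nitrogen gave a 2.0-fold lower number from compound 3 to compound 4 (0.29 log units; within the scatter). Set beside the earlier step, the change did not carry over from one core to the other: the same change on two cores in this assay, a 1.9-fold higher number (0.27 log units; within the scatter) from compound 1 to compound 2 and a 2.0-fold lower number (0.29 log units; within the scatter) from compound 3 to compound 4, 3.7-fold (0.57 log units) apart, beyond the scatter of two such steps. This shows that the step read on the core of compound 1 does not predict the step on the core of compound 3, but each single step lies within the scatter, so neither core shows a real preference between benzyl and cyclohexyl, and two cores give no rule for any other.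

Going by these compounds, whether the gap between the two steps would hold on further cores remains open. Also open, on these data alone, is how a phenethyl group or a plain methyl would read on the same amide-type nitrogen.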